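Methoxy for chloro beside a sulfonamide linker

This account rests on a few compounds, and the source may have more. Where it says the series, first, only, none or still open, it means among the compounds named here.

Measured compounds:
compound 1, `COc1ccc(C(=O)NO)cc1C(=O)Nc1ccc2c(c1)cc(C)c(=O)n2C`: 65 nM
compound 2, `Cc1cc2cc(NS(=O)(=O)c3cc(C(=O)NO)ccc3Cl)ccc2n(C)c1=O`: 560 nM

In an assay on isolated protein for inhibition of histone deacetylase 8 (Homo sapiens), read by fluorescence, with a stated time of 90 min (on this read-out lower numbers stand for stronger inhibition and higher numbers for weaker inhibition), compound 1 gives 65 nM and compound 2 gives 560 nM. Compound 2 thus stands at the higher of the two numbers and compound 1 at the lower, a gap beyond the scatter, though the two structures differ in more than one place. Compound 3, `COc1ccc(C(=O)NO)cc1S(=O)(=O)Nc1ccc2c(c1)cc(C)c(=O)n2C`, differs from compound 2 in a single place: methoxy in place of chloro on an aromatic carbon. Among the compounds with values here, no step between measured compounds isolates this change. Compound 3 is estimated at 300 nM, with a range of 100 nM to 900 nM. The expected step of a 1.9-fold lower number from compound 2 to compound 3 (0.27 log units; within the scatter) is a modest move toward stronger inhibition, near the edge of the scatter.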

Compound 3, half-maximal inhibitory concentration: 443 nM
Estimate against measurement, compound 3: 1.5-fold (0.17 log units) below; the range from low to high includes it.
By their numbers in this assay, from the lowest: compound 1; then compounds 3 and 2 (each within the scatter of the next).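

On an aromatic carbon para to a hydroxycarbamoyl group, with the sulfonamide linker kept, methoxy in place of chloro gives a 1.3-fold lower number from compound 2 to compound 3 (0.10 log units; within the scatter) in this assay, so the two groups cannot be told apart at this position. The earlier pair differed in more than one place and could not show this. No measurement shown bears on why the two groups read alike. The compounds shown leave open whether an amine or a carboxylic acid on this carbon would read differently, and whether chloro and methoxy also read alike with the amide linker of compound 1.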